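The compounds below may be only part of what the source reports. "The series", "measured", "known", "first", "only" and "open" are said of these compounds alone.

Working notes on the series. Within the data shown here, in a functional assay on SW480 cells (Homo sapiens) for cytotoxicity, read by MTT assay, with a stated time of 4 days (on this read-out higher numbers stand for weaker inhibition and lower numbers for stronger inhibition), compound 3 `C=C1C[C@]23C[C@@]1(O)CC[C@H]2c1cc(Br)c(O)c(C)c1[C@@H]3Cn1cc(-c2ccc(C(F)(F)F)cc2)nn1` gives 15200 nM, the only number among the three values shown. Compound 1 `C=C1C[C@]23C[C@@]1(O)CC[C@H]2c1cc(Br)c(O)c(C)c1[C@@H]3Cn1cc(-c2ccc(OC)cc2)nn1` in this assay sits at > 20000 nM, which is a limit of the assay and not a number. Compound 2 `C=C1C[C@]23C[C@@]1(O)CC[C@H]2c1cc(Br)c(O)c(C)c1[C@@H]3Cn1cc(-c2ccccc2)nn1` in this assay likewise sits at > 20000 nM, again a limit. The step that the two limits leave unreadable from compound 1 to compound 2 thus cannot be read. The steps of an at least 1.3-fold lower number from compound 1 to compound 3 (0.11 log units; that floor lies within the scatter) and an at least 1.3-fold lower number from compound 2 to compound 3 (0.11 log units; that floor lies within the scatter) both start from the limit of > 20000 nM in this assay, at which 2 of the 3 values shown sit, and their floors lie within the scatter, so their true size is open. Compound 4 `C=C1C[C@]23C[C@@]1(O)CC[C@H]2c1cc(Br)c(O)c(C)c1[C@@H]3Cn1cc(-c2ccc(Cl)cc2)nn1` differs from compound 3 by chloro in place of trifluoromethyl on an aromatic carbon. Among the measured compounds shown here, no measured step pairs chloro with another group on this ring, so the nearest bearing steps are those from compound 1 and compound 2 to compound 3, each of unreadable true size. The expectation is no step beyond the scatter in this assay, with a sizable chance that compound 4 is reported only as a limit. Compound 4 is estimated at 18000 nM in this assay, between 8000 nM and 40000 nM. The expected step is a 1.2-fold higher number from compound 3 to compound 4 (0.07 log units; within the scatter), within the scatter.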

Compound 4, half-maximal inhibitory concentration: 18000 nM
Beside the measured number, compound 4's estimate shows no gap at the digits printed; the measured number falls inside the stated range.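

In this assay, the step of a 1.2-fold higher number from compound 3 to compound 4 (0.07 log units; within the scatter) lies within the scatter, so chloro and trifluoromethyl at this place, para to a large group, cannot be told apart. Compound 4 and compound 3 both give numbers, while compound 1 and compound 2, with methoxy and hydrogen at this place, give only a limit. The steps of an at least 1.1-fold lower number from compound 2 to compound 4 (0.04 log units; that floor lies within the scatter) and an at least 1.1-fold lower number from compound 1 to compound 4 (0.04 log units; that floor lies within the scatter) start from that limit of the assay and their floors lie within the scatter, so their true size cannot be read: the limit of > 20000 nM in this assay, at which 2 of the 4 values shown sit.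

Going by these compounds, what an amine or a carboxylic acid at this place would do to the number remains open. Also open, on these data alone, is whether any group here gives a step beyond the scatter.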